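A few compounds are considered here, and "the series" means these few. Any claim that something is new, unique, unknown or untested is made for them only; others in the source may bear on it.

Of the compounds shown here, two have so far been read in a functional assay on HCT-116 cells (Homo sapiens) for inhibition, read by CCK-8 assay, with a stated time of 72 h, tested at 2 uM; a lower number here means less inhibition of growth, a higher number more inhibition of growth at the concentration tested. Compound 1, `Nc1ccccc1NC(=O)/C=C/c1ccc(CSc2cccc(F)c2)cc1`, gives 7.95%, and compound 2, `COc1ccc(SCc2ccc(C(=O)Nc3ccccc3N)cc2)cc1`, gives 73.3%. The gap between these two numbers lies well beyond the usual scatter, and compound 1 holds the lower place. The next compound to be read is compound 3, `Nc1ccccc1NC(=O)/C=C/c1ccc(CSCCc2ccccc2)cc1`. It keeps the core of compound 1 and alters one part of it: phenethyl in place of 3-fluorophenyl on a sulfur. Phenethyl stands in place of 3-fluorophenyl on a sulfur. Going by the values given here, no pair of measured compounds differs in only one place, so the data give no direct guide to this exchange, and any expectation remains loose. Since compound 1 sits at 7.95%, there is more room for movement upward than downward, and a moderate rise in this assay is expected, one that may only just clear the scatter. The expected change is a number 14.1 percentage points higher from compound 1 to compound 3 (beyond the scatter). Compound 3 is estimated to give 22%, with an expected range from 4% to 50%.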

Compound 3, percent growth inhibition at one concentration: 18%
Compound 3: the middle estimate sits 4 percentage points above what was measured; the range from low to high includes it.
By their numbers in this assay, from the lowest: compound 1; then compound 3; then compound 2.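

In this assay, going by these compounds alone, the exchange of 3-fluorophenyl for phenethyl on a sulfur provides the first reading of a change at a single place: a number 10.1 percentage points higher from compound 1 to compound 3 (beyond the scatter). This shows that the group on this sulfur can shift the result by a modest amount, although compound 3, at 18%, still gives limited inhibition of growth at the concentration tested. The exchange alters more than one feature at once, since the entering group has 8 heavy atoms against 7 and carries no fluorine, while both groups hold one six-membered aromatic ring of carbon only, and no measurement at hand accounts for the rise.

Within the data shown here, the single step does not separate the loss of the fluorine from the insertion of the chain, so it remains open how an unsubstituted phenyl or a benzyl on the same sulfur would read. On these data alone, it also remains open whether the trend would continue with a longer chain ending in a phenyl ring, or how a chain ending in an amine or a carboxylic acid would behave at this position.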